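The compounds below may be only part of what the source reports. "The series", "measured", "known", "first", "only" and "open" are said of these compounds alone.

Among the compounds with values here, in an ADME assay on L6 cells (Rattus norvegicus) for cytotoxicity, read by resazurin assay, with a stated time of 70 h (a higher number here means a weaker inhibitor, a lower number a stronger inhibitor), three compounds sharing one core have numbers so far: compound 1 (`CC(=O)Oc1ccc2c(c1)C(C)=CC(C)(C)N2Cc1cccc(Cl)c1`) gives 29000 nM, compound 2 (`CC(=O)Oc1ccc2c(c1)C(C)=CC(C)(C)N2Cc1ccc(C(F)(F)F)cc1`) gives 14000 nM, and compound 3 (`CC(=O)Oc1ccc2c(c1)C(C)=CC(C)(C)N2Cc1cccc(C)c1`) gives 28000 nM. Compound 3 therefore lies within the usual scatter of both others. Compound 4 (`COc1ccc(CN2c3ccc(OC(C)=O)cc3C(C)=CC2(C)C)cc1`) has 4-methoxyphenyl in place of 3-methylphenyl on a saturated chain carbon bound to a nitrogen on an aromatic ring in a ring. Within the data shown here, the only measured single-place step, a 1.0-fold lower number from compound 1 to compound 3 (0.02 log units; within the scatter), puts methyl in place of chloro and stays within the scatter. Among the measured compounds shown here, it bears on this change only loosely, as no measured compound carries methoxy. No step beyond the scatter is therefore expected in this assay. The expected step is a 1.2-fold lower number from compound 3 to compound 4 (0.07 log units; within the scatter). The estimate for compound 4 is 24000 nM, with an expected range of 10000 nM to 55000 nM.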

Compound 4, half-maximal inhibitory concentration: 15000 nM
For compound 4 the middle estimate is 1.6-fold (0.20 log units) above the measured one; the measured number falls inside the stated range.
By their numbers in this assay, from the lowest: compounds 2, 4, 3 and 1 (each within the scatter of the next, the first and the last beyond it).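

Methoxy is new among these compounds, and in this assay the change at this place gives a 1.9-fold lower number from compound 3 to compound 4 (0.27 log units; within the scatter) and stays within the scatter. The same holds for 4-methoxyphenyl in place of 3-chlorophenyl, with a 1.9-fold lower number from compound 1 to compound 4 (0.29 log units; within the scatter) as the step, and for methoxy in place of trifluoromethyl, with a 1.1-fold higher number from compound 2 to compound 4 (0.03 log units; within the scatter) as the step. Nothing measured here explains these small steps. Still open, going by these compounds, is whether an amine or a carboxylic acid on this aromatic ring would give a step beyond the scatter.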